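Ethyl to chloro in a cell assay

This account rests on a few compounds, and the source may have more. Where it says the series, first, only, none or still open, it means among the compounds named here.

Measured so far:
Compound 1 [ `CCc1ccc(-c2nc3ccccn3c2Sc2ccccc2)cc1` ]: 61700 nM
Compound 2 [ `c1ccc(Sc2c(-c3cccc4ccccc34)nc3ccccn23)cc1` ]: > 100000 nM (a limit, not a number)

Both compounds were tested in a functional assay on U-87MG ATCC cells for inhibition, with U-87 MG (Homo sapiens) as the target, read by MTT assay, with a stated time of 48 h; a higher number here means a weaker inhibitor, a lower number a stronger inhibitor. Among the measured compounds shown here, compound 1 holds the only exact number in the set, and the result for compound 2 is a limit of the assay.

Compound 3 [ `Clc1ccc(-c2nc3ccccn3c2Sc2ccccc2)cc1` ] has not yet been measured. It differs from compound 1 in one place [ chloro in place of ethyl on an aromatic carbon ], with chloro in place of ethyl on an aromatic carbon, para to a large group. For the measured compounds named here, no step between measured compounds gauges this change. The expectation therefore rests on compound 1 at 61700 nM alone, and no shift beyond the scatter is expected in this assay. The estimated 1.1-fold lower number from compound 1 to compound 3 (0.05 log units; within the scatter) is accordingly expected to be small, with no firm direction. Compound 3 is expected to give about 55000 nM, with an estimated range from 22000 nM to 100000 nM.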

Compound 3, half-maximal inhibitory concentration: 30200 nM
For compound 3 the middle estimate is 1.8-fold (0.26 log units) above the measured one, within the range that was stated.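

In this assay, replacing ethyl with chloro on the aromatic carbon para to a large group gives a 2.0-fold lower number from compound 1 to compound 3 (0.31 log units; beyond the scatter). Among the compounds shown here, this is the first step that can be read in the set, and it shows that the assay responds to a change at this position, even though the step is modest. For the compounds shown here, compound 2 offers no second exact value to set beside it, as it is the one compound resting on a limit of the assay: the limit of > 100000 nM in this assay, at which 1 of the 3 values shown sits.

With only ethyl and chloro compared at this position, the compounds shown cannot say which feature of the change lies behind the step. They also leave open how a bromine atom, a methoxy group, an amine or a carboxylic acid in the same place would read.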